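Isobutyl on the phenyl: compound 3 toward compound 4

The compounds below may be only part of what the source reports. "The series", "measured", "known", "first", "only" and "open" are said of these compounds alone.

Going by the values given here, the three measured members share one core. Compound 1, `COc1ccccc1NC(=O)c1ccc(OCCCN2CCN(c3ccccc3OC)CC2)cc1`, gives 79.4 nM in an assay on Prostate gland (Oryctolagus cuniculus) for inhibition of Adrenergic receptor alpha-1 (Homo sapiens); a higher number here means weaker binding, a lower number tighter binding. Compound 2, `COc1ccccc1N1CCN(CCC(Oc2ccc(NC(=O)c3ccccc3OCCCC(=O)O)cc2)c2ccccc2)CC1`, gives 79.4 nM in this assay. Compound 3, `COc1ccccc1N1CCN(CCC(Oc2ccc(C(=O)Nc3ccccc3OCCCC(=O)O)cc2)c2ccccc2)CC1`, gives 25.1 nM in this assay and so holds the lowest of the three numbers; its gaps to compound 1 and to compound 2 both lie beyond the scatter, so compound 3 is the tightest binder of the set so far.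

Compound 4, `COc1ccccc1N1CCN(CCC(Oc2ccc(C(=O)Nc3ccccc3OCCCC(=O)O)cc2)c2ccc(CC(C)C)cc2)CC1`, differs from compound 3 in one place: isobutyl in place of hydrogen on an aromatic carbon. Cut one bond further out, the change reads phenyl to 4-isobutylphenyl. Among the compounds with values here, no pair among the measured compounds carries this kind of difference, so there is no reference step to lean on.

Without such a reference the expectation rests on the starting point alone. In this assay the step is estimated as a 1.3-fold lower number from compound 3 to compound 4 (0.10 log units; within the scatter), that is, no change beyond the scatter, with the direction left open. Compound 4 is therefore expected to give about 20 nM in this assay, within a range from 6 nM to 65 nM, the width reflecting the absence of any measured precedent for this change.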

Compound 4, dissociation constant: 2000 nM
Compound 4: middle estimate off by 100-fold (2.00 log units), on the low side, outside the stated range (above it).
By their numbers in this assay, from the lowest: compound 3; then compounds 1 and 2 (each within the scatter of the next); then compound 4.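

In this assay the change of phenyl to 4-isobutylphenyl brings an 80-fold higher number from compound 3 to compound 4 (1.90 log units; beyond the scatter) and takes the series from its tightest binder to its weakest. Going by these compounds alone, this is the first reading at this position, since the earlier compounds carry no substituent on this ring and gave no sign of how it responds. It shows that the aromatic carbon para to a large group does not accept isobutyl without a heavy loss of binding in this series, at least on the core of compound 3. No measurement at hand accounts for the size of this step, and the cause of the loss remains unassigned.

A single substituent cannot separate the effect of the position from that of the group, so a smaller group at the same carbon, such as methyl or a fluorine atom, would show whether the loss is graded or specific to isobutyl. Also open, on these data alone, is whether isobutyl at other positions on this ring, or on the reversed amide of compound 2, gives a step of similar size.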